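Chloro for fluoro on two related cores

The compounds below may be only part of what the source reports. "The series", "measured", "known", "first", "only" and "open" are said of these compounds alone.

Compound 1 `CS(=O)(=O)c1ccc(F)cc1NCC1=NCCN1` gives 91% in a functional assay on CHO cells for agonist activity at Alpha-2C adrenergic receptor (Homo sapiens); a lower number here means a smaller maximal response, a higher number a larger maximal response. Its fluoro-to-chloro partner, compound 3 `CS(=O)(=O)c1ccc(Cl)cc1NCC1=NCCN1`, gives 81%, and the change chloro in place of fluoro on an aromatic carbon made the step of a number 10 percentage points lower from compound 1 to compound 3 (within the scatter). Compound 2 `CS(=O)(=O)c1cc(F)ccc1NCC1=NCCN1` has the same atoms as compound 1 joined differently; how the two cores differ is not broken down here. In this assay compound 2 gives 32%, the lowest of the three values. Compound 4 `CS(=O)(=O)c1cc(Cl)ccc1NCC1=NCCN1` is the not yet measured chloro counterpart of compound 2, with the change (chloro in place of fluoro on an aromatic carbon). It is the same kind of change as from compound 1 to compound 3, but the place differs: there the chloro sits meta to a group of 7 heavy atoms and para to a methylsulfonyl group, here meta to a methylsulfonyl group and para to a group of 7 heavy atoms. Since the step from compound 1 to compound 3 stayed within the scatter, he expects a step of similar size, a number 4 percentage points lower from compound 2 to compound 4 (within the scatter), from compound 2 to compound 4. He estimates compound 4 at 28%, between 10% and 50%.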

Compound 4, largest response reached (reported as maximum), in percent of the reference or control that the assay uses: 54%
Beside the measured number, compound 4's estimate is 26 percentage points below it, outside the stated range (above it).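

In this assay, chloro in place of fluoro on an aromatic carbon made the new step of a number 22 percentage points higher from compound 2 to compound 4 (beyond the scatter). The same change therefore did not give the same result on the two cores: the same change on two cores in this assay, a number 10 percentage points lower (within the scatter) from compound 1 to compound 3 and a number 22 percentage points higher (beyond the scatter) from compound 2 to compound 4, 32 percentage points apart, beyond the scatter of two such steps. This shows that the step seen on one core could not be carried over to the other in this pair of cores, but two pairs give no general rule and do not show why the steps differ.

The compounds shown carry only fluoro or chloro at these places. From the compounds shown here alone, whether a nitrile, a methoxy group or an amine in place of the halogen would also give different steps on the two cores remains open.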